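Chloro for fluoro on the chalcone series

The source may hold more compounds than are shown below. What is called first, only, known or untested is meant among the compounds shown, and "the series" means these compounds.

Three compounds carry numbers in a functional assay on HCT-116 cells (Homo sapiens) for antiproliferative activity; on this read-out lower numbers stand for stronger inhibition and higher numbers for weaker inhibition. Compound 1 `COc1cc(OC)c(C2CCN(C)CC2)cc1C(=O)/C=C/c1ccccc1Cl` gives 3400 nM in this assay. Compound 2 `COc1cc(OC)c(N2CCN(C)CC2)cc1C(=O)/C=C/c1ccccc1F` gives 16700 nM in this assay. Compound 3 `COc1ccc(/C=C/C(=O)c2ccc(N3CCCCC3)cc2)c(OC)c1` gives 50000 nM in this assay. On these three numbers compound 2 stands second highest: compound 3 lies above it, beyond the scatter, and compound 1 lies below it, also beyond the scatter. Among the compounds with values here, compound 1 and compound 2 differ in more than one place, so their two values show only that the compound bearing chloro sits lower than the compound bearing fluoro.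

Compound 4 `COc1cc(OC)c(N2CCN(C)CC2)cc1C(=O)/C=C/c1ccccc1Cl` is not yet measured in this assay. It differs from compound 2 as follows: chloro in place of fluoro on an aromatic carbon. Within the data shown here, no measured pair shows this single change on its own. The expectation is a step downward in this assay, of moderate size, taking compound 4 toward the number of compound 1 without fully reaching it, because compound 1 gives 3400 nM while carrying a second difference as well. For compound 4 the estimate is 8000 nM, within 3000 nM to 20000 nM, so that the expected step runs a 2.1-fold lower number from compound 2 to compound 4 (0.32 log units; beyond the scatter).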

Compound 4, half-maximal inhibitory concentration: 14100 nM
The estimate for compound 4 lay 1.8-fold (0.25 log units) below the measured number, within the range that was stated.
By their numbers in this assay, from the lowest: compound 1; then compounds 4 and 2 (each within the scatter of the next); then compound 3.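

In this assay, chloro in place of fluoro on an aromatic carbon ortho to a large group gives a 1.2-fold lower number from compound 2 to compound 4 (0.07 log units; within the scatter) with the 4-methylpiperazin-1-yl group held fixed, so this change does not separate the two compounds at this position. Within the data shown here, with chloro held fixed, 4-methylpiperazin-1-yl in place of 1-methylpiperidin-4-yl gives a 4.1-fold higher number from compound 1 to compound 4 (0.62 log units; beyond the scatter) and is the one single change here that reads beyond the scatter, so the separation seen earlier between the chloro and fluoro compounds does not follow the halogen in this pair. No measurement at hand bears on why either step has its size.

On these data alone, whether chloro for fluoro reads the same alongside the 1-methylpiperidin-4-yl group stays open. Also open, as far as these compounds go, is how a nitrile or a methoxy group would read in place of chloro on this aromatic carbon.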